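The source may hold more compounds than are shown below. What is called first, only, known or untested is meant among the compounds shown, and "the series" means these compounds.

Measured so far: compound 1 `Cc1nc(-c2ccc(C(F)(F)F)cc2)sc1CNc1ccc(C(=O)O)cc1`, compound 2 `O=C(O)CCCc1ccc(NCc2cccc(Oc3ccccc3)c2)cc1`, compound 3 `O=C(O)COc1ccc(NCc2cccc(Oc3ccccc3)c2)cc1`. In a functional assay on CHO cells for agonist activity at Free fatty acid receptor 1 (Homo sapiens) (a higher number here means that more compound is needed for the effect, a lower number that less compound is needed), compound 2 gives 1120 nM. Compound 3 gives 2040 nM in this assay. For compound 1 only a limit of the assay, not a number, is known: < 10000 nM.

Compound 1 therefore cannot be placed among the numbers; it stands only at the limit of < 10000 nM in this assay, at which 1 of the 3 values shown sits. Compound 4 `Cc1nc(-c2ccc(C(F)(F)F)cc2)sc1CNc1ccc(C(C)CC(=O)O)cc1` differs from compound 1 by 1-(carboxymethyl)ethyl in place of carboxy on an aromatic carbon. Among the compounds with values here, no measured step covers this change. Within the data shown here, the one measured step, a 1.8-fold higher number from compound 2 to compound 3 (0.26 log units; within the scatter), alters the acid-bearing chain on the same kind of ring and stays within the scatter, so chain changes of that sort need not move the number much. Compound 4 is expected at 400 nM, range 60 nM to 3000 nM. The expected step is a step that the limit leaves unreadable from compound 1 to compound 4.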

Compound 4, half-maximal effective concentration: 58.9 nM
Compound 4: middle estimate off by 6.8-fold (0.83 log units), on the high side; the measured number lies below the stated range.
By their numbers in this assay, from the lowest: compound 4; then compounds 2 and 3 (each within the scatter of the next).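

Within the data shown here, no step from compound 1 to compound 4 can be read, as compound 1 carries only a limit of the assay: the limit of < 10000 nM in this assay, at which 1 of the 4 values shown sits. The compounds shown leave open whether, and how far, 1-(carboxymethyl)ethyl in place of carboxy shifts the number on this core.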